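A Pyridin-4-yl Swap Repeated on a Chloro Analogue

The compounds below may be only part of what the source reports. "The series", "measured", "known", "first", "only" and "open" are said of these compounds alone.

Measured in an assay on CHO cells for positive allosteric modulation of adenosine receptor A1 (Homo sapiens), read by ERK phosphorylation, tested at 3 uM; a higher number here means a weaker effect of the compound at the concentration tested, a lower number a stronger effect:
compound 1, `Nc1sc(-c2cncnc2)cc1C(=O)c1ccccc1`: 18%
compound 2, `Nc1sc(-c2ccncc2)cc1C(=O)c1ccccc1`: 23%
compound 3, `Nc1sc(-c2cncnc2)cc1C(=O)c1ccc(Cl)cc1`: 7%

The change from compound 1 to compound 2, (pyridin-4-yl in place of pyrimidin-5-yl on an aromatic carbon), moved the read-out by a number 5 percentage points higher from compound 1 to compound 2 (within the scatter). Compound 4, `Nc1sc(-c2ccncc2)cc1C(=O)c1ccc(Cl)cc1`, has yet to be measured; it differs from compound 3 by pyridin-4-yl in place of pyrimidin-5-yl on an aromatic carbon, the same kind of change, though not the same: in compound 3 the ring atom two ring bonds away bears a group of 9 heavy atoms, in compound 1 a group of 8. The two cores differ by chloro in place of hydrogen on an aromatic carbon, which gave a number 11 percentage points lower from compound 1 to compound 3 (beyond the scatter), leaving compound 3 with the lowest of the three numbers. Compound 4 is expected to shift by a number 5 percentage points higher from compound 3 to compound 4 (within the scatter), since the earlier step of the same kind was a number 5 percentage points higher from compound 1 to compound 2 (within the scatter). Compound 4 is therefore estimated at 12%, between 3% and 25%.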

Compound 4, a percentage reported as activity, at one concentration (the size of the read-out at that concentration, not a potency): 44%
The estimate for compound 4 lay 32 percentage points below the measured number; measured number outside the range, above it.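

In this assay, the pyridin-4-yl swap did not carry over from one core to the other, giving a number 37 percentage points higher from compound 3 to compound 4 (beyond the scatter), and the two instances disagree: the same change on two cores in this assay, a number 5 percentage points higher (within the scatter) from compound 1 to compound 2 and a number 37 percentage points higher (beyond the scatter) from compound 3 to compound 4, 32 percentage points apart, beyond the scatter of two such steps. The chloro change also reversed its direction once pyridin-4-yl was in place, giving a number 21 percentage points higher from compound 2 to compound 4 (beyond the scatter): the same change on two cores in this assay, a number 11 percentage points lower (beyond the scatter) from compound 1 to compound 3 and a number 21 percentage points higher (beyond the scatter) from compound 2 to compound 4, 32 percentage points apart, beyond the scatter of two such steps. Across these four compounds, the effect of each change therefore depends on the other, but this single set of four shows neither why that is so nor how either change would behave on any further core.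

As far as these compounds go, whether a fluoro or a methoxy group in place of the chloro would show the same dependence remains open.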